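A Second Methyl on the Saturated Ring

This account rests on a few compounds, and the source may have more. Where it says the series, first, only, none or still open, it means among the compounds named here.

Measured so far:
compound 1, `O=C(c1c(F)cccc1F)N1CCc2nc(COc3cccc(F)c3)oc2C1`: 324 nM; 370 nM (2 entries)
compound 2, `CC1c2oc(COc3ccccc3)nc2CCN1C(=O)c1ccc(F)cc1`: 750 nM

Of the compounds shown here, two have been measured in a functional assay on HEK293 cells for positive allosteric modulation of metabotropic glutamate receptor 5 (Homo sapiens), read by calcium flux; a lower number here means that less compound is needed, a higher number that more compound is needed for the effect. Compound 1 (`O=C(c1c(F)cccc1F)N1CCc2nc(COc3cccc(F)c3)oc2C1`) is recorded more than once, (the several entries of compound 1 in this assay, 324 nM; 370 nM (2 entries)), and compound 1 gives 324 nM; 370 nM (2 entries). Compound 2 (`CC1c2oc(COc3ccccc3)nc2CCN1C(=O)c1ccc(F)cc1`) gives 750 nM; a further entry for compound 2 reports no single number. For the measured compounds named here, only one number for compound 2 is thus known, and no measured pair differs in a single place, so the two values can only be set side by side. Compound 3 (`CC1(C)c2oc(COc3ccccc3)nc2CCN1C(=O)c1ccc(F)cc1`) is not yet measured. It differs from compound 2 in one place: methyl in place of hydrogen on a saturated ring carbon. Going by the values given here, no measured pair shows what adding a methyl in this way does, so the size of the step in this assay can only be estimated; a modest rise in the concentration needed, or no change beyond the usual scatter, seems the most likely outcome. Compound 3 is therefore expected to give about 1100 nM, within 350 nM to 3500 nM. The expected step from compound 2 to compound 3 is a 1.5-fold higher number from compound 2 to compound 3 (0.17 log units; within the scatter).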

Compound 3, half-maximal effective concentration: 510 nM
For compound 3 the middle estimate is 2.2-fold (0.33 log units) above the measured one; the measured number falls inside the stated range.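

For the compounds shown here, this is the first pair that differs in one place only, so it gives the first direct reading of a change at this position: in this assay, putting methyl in place of hydrogen on the saturated ring carbon next to the ring nitrogen gives a 1.5-fold lower number from compound 2 to compound 3 (0.17 log units; within the scatter). That step lies within the scatter, so compound 2 and compound 3 cannot be told apart, and this ring carbon can carry two methyl groups with no change that this assay can resolve. Nothing measured here gives a reason for this result, and the repeat entries of compound 1 do not bear on this position.

The compounds shown leave open what this carbon gives with hydrogen alone in place of both methyl groups, and whether a longer chain such as ethyl, a hydroxyl or an amine would fare the same there. They also leave open whether the same change would read alike with other groups elsewhere on the molecule, since this single pair carries a (4-fluorophenyl)carbonyl group and compound 1 differs from both compounds in more than one place.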